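Moving a Nitrile: 4-Cyanophenyl to 2-Cyanophenyl

The source may hold more compounds than are shown below. What is called first, only, known or untested is meant among the compounds shown, and "the series" means these compounds.

In a functional assay on HepG2 cells (Homo sapiens) for antiproliferative activity, read by MTT assay, with a stated time of 72 h (on this read-out lower numbers stand for stronger inhibition and higher numbers for weaker inhibition), three compounds have numbers so far
Compound 1 `COc1cc2c(Nc3ccc(C#N)cc3)ncnc2cc1OCCCN1CCCCC1` gives 20700 nM
Compound 2 `CCOC(=O)C1CCN(CCCOc2cc3ncnc(Nc4ccc(C#N)cc4)c3cc2OC)CC1` gives 57700 nM
Compound 3 `CCN1CCN(CCCOc2cc3ncnc(Nc4ccc(C#N)cc4)c3cc2OC)CC1` gives 9580 nM

Compound 3 holds the lowest number of the three, which means the strongest inhibition here: a 2.2-fold lower number from compound 1 to compound 3 (0.33 log units; beyond the scatter) and a 6.0-fold lower number from compound 2 to compound 3 (0.78 log units; beyond the scatter) are both beyond the usual scatter. The next compound, compound 4 `CCN1CCN(CCCOc2cc3ncnc(Nc4ccccc4C#N)c3cc2OC)CC1`, has the same atoms joined differently: 2-cyanophenyl in place of 4-cyanophenyl on a nitrogen on an aromatic ring.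

Among the measured compounds shown here, no measured step touches this group. All three, including a 2.8-fold higher number from compound 1 to compound 2 (0.45 log units; beyond the scatter) as well as the two above, change the group on the saturated chain, so they offer only a sense of scale: modest steps. The direction cannot be read from them. A modest rise is expected, because compound 3 at 9580 nM is already the lowest of the set and a further drop seems the less likely outcome. The expected change is a 2.1-fold higher number from compound 3 to compound 4 (0.32 log units; beyond the scatter) in this assay as an estimate with wide uncertainty. For compound 4 the estimated value is 20000 nM (expected range 6500 nM to 60000 nM).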

Compound 4, half-maximal inhibitory concentration: 2110 nM
Estimate against measurement, compound 4: 9.5-fold (0.98 log units) above; measured number below the stated range.
By their numbers in this assay, from the lowest: compound 4; then compound 3; then compound 1; then compound 2.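

Among the compounds shown here, until this result, every step had changed the group on the saturated chain, so nothing showed whether the aryl group on the nitrogen mattered. In this assay, replacing 4-cyanophenyl with 2-cyanophenyl gives a 4.5-fold lower number from compound 3 to compound 4 (0.66 log units; beyond the scatter), so this part of the molecule also affects the read-out, even though the change only moves the nitrile around the ring. The two groups match in heavy atoms, ring type and hydrogen-bond counts, so those tallies cannot separate them, and nothing available here bears on why the move lowers the number.

The compounds shown leave open how 3-cyanophenyl, the remaining placement of the nitrile, would compare, and whether a different group at the same spot, such as 2-chlorophenyl or 2-methoxyphenyl, would do as well as 2-cyanophenyl. From the compounds shown here alone, it is also open whether the step would carry over to the piperidin-1-yl and 4-(ethoxycarbonyl)piperidin-1-yl compounds, since 2-cyanophenyl is seen here only alongside 4-ethylpiperazin-1-yl.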